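Ethoxycarbonyl to carboxy, repeated on a second core

A few compounds are considered here, and "the series" means these few. Any claim that something is new, unique, unknown or untested is made for them only; others in the source may bear on it.

Measured so far in an assay on isolated protein for inhibition of DNA nucleotidylexotransferase (Homo sapiens), read by scintillation counting, with a stated time of 10 min; a higher number here means a weaker inhibitor, a lower number a stronger inhibitor:
compound 1 `CCOC(=O)C(=O)CC(=O)/C=C/c1cn(CC(=O)N2CCOCC2)c2ccccc12` – only a limit, > 40 uM
compound 2 `O=C(/C=C/c1cn(CC(=O)N2CCOCC2)c2ccccc12)CC(=O)C(=O)O` – 24 uM
compound 3 `CCOC(=O)C(=O)CC(=O)/C=C/c1cc(C(=O)c2ccccc2)cn1Cc1ccccc1` – only a limit, > 40 uM

Compound 2 differs from compound 1 by hydrogen in place of ethyl on an oxygen next to a carbonyl group, and that change gave an at least 1.6-fold lower number from compound 1 to compound 2 (0.22 log units; that floor lies within the scatter). Compound 3 stands at a limit of this assay; (the limit of > 40 uM in this assay, at which 2 of the 3 values shown sit). How the core of compound 3 differs from the core of compound 1 is not broken down here. Compound 4 `O=C(/C=C/c1cc(C(=O)c2ccccc2)cn1Cc1ccccc1)CC(=O)C(=O)O` differs from compound 3 by hydrogen in place of ethyl on an oxygen next to a carbonyl group; the place is the same, so this is the same change. Because compound 1 to compound 2 gave an at least 1.6-fold lower number from compound 1 to compound 2 (0.22 log units; that floor lies within the scatter), a step of similar size is expected here, an at least 1.3-fold lower number from compound 3 to compound 4 (0.12 log units; that floor lies within the scatter). Compound 4 is therefore estimated at 30 uM, with the expected range 8 uM to 100 uM.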

Compound 4, concentration for 50% inhibition: 16 uM
Compound 4: middle estimate off by 1.9-fold (0.27 log units), on the high side; low and high end bracket the measured number.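

In this assay, ethoxycarbonyl to carboxy on the second core gave an at least 2.5-fold lower number from compound 3 to compound 4 (0.39 log units; beyond the scatter), so the number fell on this core as well as on the first, although only the floor of this second step lies beyond the scatter. Both steps start from a limit rather than a measured number, so they show a shared direction but not a shared size: the same change on two cores in this assay, an at least 1.6-fold lower number (0.22 log units; that floor lies within the scatter) from compound 1 to compound 2 and an at least 2.5-fold lower number (0.39 log units; beyond the scatter) from compound 3 to compound 4; the limit leaves it open whether they differ. How much of the change carries from one core to the other therefore cannot be read from these compounds.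

The compounds shown leave open how a primary amide or a methyl ester in place of the carboxy would read in this assay. They also leave open whether the same change holds on any further core.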